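Replacing the hydroxyindanyl amine substituent with a furanylmethyl group

The compounds below may be only part of what the source reports. "The series", "measured", "known", "first", "only" and "open" are said of these compounds alone.

Of the compounds shown here, three sharing one core have been measured in an assay on CHO cells for agonist activity at 5-hydroxytryptamine receptor 1D (Homo sapiens), read by GTPgammaS binding; on this read-out higher numbers stand for an effect only at larger amounts of compound and lower numbers for an effect already at smaller amounts. Compound 1 `c1ccc(C2CCCCN2C2CCN(CCCc3c[nH]c4ccc(-n5cnnc5)cc34)CC2)cc1` gives 4.7 nM, compound 3 `CC(=O)Nc1ccc([C@H](C)NCC2CCN(CCCc3c[nH]c4ccc(-n5cnnc5)cc34)CC2)cc1` gives 3 nM, and compound 2 `O[C@@H]1Cc2ccccc2[C@H]1NC1CCN(CCCc2c[nH]c3ccc(-n4cnnc4)cc23)CC1` gives 13 nM. Compound 2 thus stands at the highest of the three numbers in this assay, with the gap to compound 1 and the gap to compound 3 both beyond the usual scatter.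

Compound 4 `c1cc(CNC2CCN(CCCc3c[nH]c4ccc(-n5cnnc5)cc34)CC2)co1` differs from compound 2 in one place: (furan-3-yl)methyl in place of 2-hydroxy-2,3-dihydro-1H-inden-1-yl on an amine nitrogen. Among the compounds with values here, no measured pair shows this particular change, so its effect cannot be read from the data directly; what can be said is that compound 3, which also carries a secondary amine bearing an arylmethyl-type group rather than a ring-fused substituent, gives 3 nM. On that basis compound 4 is expected to give a somewhat lower number than compound 2, a step of a 1.9-fold lower number from compound 2 to compound 4 (0.27 log units; within the scatter), though one that could still fall within the scatter. Compound 4 is therefore estimated at 7 nM, with a range from 2.5 nM to 20 nM.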

Compound 4, half-maximal effective concentration: 7.1 nM
For compound 4 the middle estimate is 1.0-fold (0.01 log units) below the measured one, and the stated range covers the measured number.
By their numbers in this assay, from the lowest: compounds 3, 1, 4 and 2 (each within the scatter of the next, the first and the last beyond it).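

In this assay, replacing 2-hydroxy-2,3-dihydro-1H-inden-1-yl with (furan-3-yl)methyl on the amine nitrogen gives a 1.8-fold lower number from compound 2 to compound 4 (0.26 log units; within the scatter), so this position accepts the exchange without a shift that stands out from the scatter. The hydrogen-bond donor and the defined stereocentres of the departing group are absent from the entering one, so, for this pair, neither is needed to keep the number at this level. Nothing available explains this result.

This single exchange alters the ring system, the hydroxyl and the stereocentres together, so their separate contributions cannot be told apart. From the compounds shown here alone, it also remains open how a (furan-2-yl)methyl group, a plain benzyl group or a simple methyl group on this nitrogen would read out.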